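A Bromo Swap on the 4-Chlorophenyl Ring

The source may report more compounds than this note shows. Statements on the series, on what has been measured and on what is new or still open speak of the compounds shown alone.

Measured in an ADME assay on HaCaT cells (Homo sapiens) for inhibition, read by sulforhodamine B assay, with a stated time of 48 h; on this read-out higher numbers stand for weaker inhibition of growth and lower numbers for stronger inhibition of growth:
- compound 1 `CC(C)(C)NCc1c(C(=O)O)nn(-c2ccc(Cl)cc2)c1-c1ccc(F)cc1`: 28700 nM
- compound 2 `CC(C)(C)NCc1c(C(=O)O)nn(-c2ccc(Cl)cc2)c1-c1ccc(Cl)cc1`: 87500 nM

Compound 2 has the higher of the two numbers, which here means the weaker inhibition of growth. Compound 3 `CC(C)(C)NCc1c(C(=O)O)nn(-c2ccc(Cl)cc2)c1-c1ccc(Br)cc1` differs from it by one change: bromo in place of chloro on an aromatic carbon. Among the compounds with values here, only one measured step bears on this, the modest 3.0-fold higher number from compound 1 to compound 2 (0.48 log units; beyond the scatter), where chloro replaced fluoro. A single step is thin evidence, so a smaller rise in this assay is expected, possibly none beyond the scatter. The expected change is a 1.3-fold higher number from compound 2 to compound 3 (0.10 log units; within the scatter). For compound 3 the estimated value is 110000 nM, with an expected range of 50000 nM to 230000 nM.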

Compound 3, concentration for 50% growth inhibition: > 542000 nM
Compound 3: a limit, no number (the forecaster's own chance of this, stated with the estimate: 20%); at least 4.9-fold (0.69 log units) between middle value and limit.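

Compound 3 gives a limit of the assay, not a number: the limit of > 542000 nM in this assay, at which 1 of the 3 values shown sits. In this assay, bromo in place of chloro on this ring gives an at least 6.1-fold higher number from compound 2 to compound 3 (0.79 log units; beyond the scatter), so the rise seen from fluoro to chloro continues with the next halogen. Across the series, bromo in place of fluoro gives an at least 18-fold higher number from compound 1 to compound 3 (1.27 log units; beyond the scatter), a large move towards weaker inhibition of growth from one atom changed.

On these data alone, it remains open whether a methyl or methoxy group here would follow the same trend. These three halogens alone cannot explain why the numbers rise.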